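This account rests on a few compounds, and the source may have more. Where it says the series, first, only, none or still open, it means among the compounds named here.

Measured so far:
- compound 2 `Cc1cnc(Nc2ccc([N+](=O)[O-])cc2)nc1Nc1nc2ccccc2s1`: 22500 nM
- compound 3 `Cc1cnc(Nc2ccc(S(N)(=O)=O)cc2)nc1Nc1nc2ccccc2s1`: 16800 nM
- compound 1 `Cc1ccc2nc(Nc3nc(Nc4ccc(S(C)(=O)=O)cc4)ncc3F)sc2c1`: 14300 nM

In a functional assay on MDA-MB-231 cells (Homo sapiens) for antiproliferative activity, read by MTT assay, with a stated time of 48 h (on this read-out lower numbers stand for stronger inhibition and higher numbers for weaker inhibition), compound 2 gives the highest of the three numbers, but its distance to the others is small: compound 3 gives 16800 nM and compound 1 gives 14300 nM, and each of these lies within the scatter of compound 2. The three compounds therefore cannot be placed in any order on the numbers shown.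

Compound 4 `Cc1cnc(Nc2cccc(F)c2)nc1Nc1nc2ccccc2s1` has not yet been measured. It differs from compound 2 in one place: 3-fluorophenyl in place of 4-nitrophenyl on a nitrogen on an aromatic ring. Going by the values given here, the one measured step that bears on this position is a 1.3-fold lower number from compound 2 to compound 3 (0.13 log units; within the scatter), a swap of the group on the same aromatic ring that left the number essentially where it was. Among the compounds with values here, there is no measured step that removes all hydrogen-bond acceptors from this ring, so the expectation rests on that single step and on how narrow the whole set is. The expected step from compound 2 to compound 4 in this assay is therefore none beyond the scatter, a 1.1-fold lower number from compound 2 to compound 4 (0.05 log units; within the scatter). Compound 4 is estimated at 20000 nM, with a range from 7000 nM to 60000 nM.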

Compound 4, half-maximal inhibitory concentration: > 50000 nM
Compound 4 was reported as a limit; the forecaster's own chance of this, stated with the estimate: 10%; middle value at least 2.5-fold (0.39 log units) from the limit.
By their numbers in this assay, from the lowest: compounds 1, 3 and 2 (each within the scatter of the next). At a limit, above all of these: compound 4.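

Compound 4 is reported only as a limit in this assay, > 50000 nM. Even so, the group on this nitrogen proves able to move the number: 3-fluorophenyl in place of 4-nitrophenyl gives an at least 2.2-fold higher number from compound 2 to compound 4 (0.34 log units; beyond the scatter), whereas the earlier swap on the same ring, a 1.3-fold lower number from compound 2 to compound 3 (0.13 log units; within the scatter), did not shift it beyond the scatter. The full size of the new step cannot be read from a limit: the limit of > 50000 nM in this assay, at which 1 of the 4 values shown sits.

This change replaces nitro with fluorine and also moves the substituent's place on the ring, and the compounds shown cannot separate those two parts, which 4-fluorophenyl or 3-nitrophenyl on this nitrogen could begin to do. They also leave open how this ring would read carrying an amine or a carboxylic acid.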